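Methoxy in Place of Methyl, Tried a Second Time

This account rests on a few compounds, and the source may have more. Where it says the series, first, only, none or still open, it means among the compounds named here.

Three compounds have been measured in a functional assay on HepG2 cells (Homo sapiens) for antiproliferative activity, read by MTT assay, with a stated time of 48 h; on this read-out lower numbers stand for stronger inhibition and higher numbers for weaker inhibition:
- compound 1, `Cc1ccc(-c2ccc3c(c2)C(=O)C(=O)N3)cc1`, gives 6000 nM
- compound 2, `COc1ccc(-c2ccc3c(c2)C(=O)C(=O)N3)cc1`, gives 960 nM
- compound 3, `COc1ccc(-c2ccc3c(c2)C(=O)C(=O)N3Cc2ccc(C)cc2)cc1`, gives 330 nM

Compound 1 and compound 2 differ in a single spot, (methoxy in place of methyl on an aromatic carbon), and this change brought a 6.3-fold lower number from compound 1 to compound 2 (0.80 log units; beyond the scatter). Compound 3 carries the substituent of compound 2 and adds a 4-methylbenzyl on the ring nitrogen, which brought a 2.9-fold lower number from compound 2 to compound 3 (0.46 log units; beyond the scatter). Compound 3 therefore has the lowest number of the three; the difference between its core and that of compound 1 is not broken down here.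

Compound 4, `COc1ccc(CN2C(=O)C(=O)c3cc(-c4ccc(OC)cc4)ccc32)cc1`, has not yet been tested. It differs from compound 3 in one spot, (methoxy in place of methyl on an aromatic carbon), which, cut one bond further out, reads 4-methylbenzyl to 4-methoxybenzyl. The place line is the same as in the earlier change, so this is the same change seen once already, though on the benzyl rather than on the ring that the earlier change touched.

Among the measured compounds shown here, for compound 4 in this assay the expected step is a 1.8-fold lower number from compound 3 to compound 4 (0.26 log units; within the scatter), set smaller than the earlier step because of a 6.3-fold lower number from compound 1 to compound 2 (0.80 log units; beyond the scatter), since that step arose on a different ring of the molecule and only one example exists. Compound 4 is estimated at 180 nM, with a likely range from 70 nM to 500 nM.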

Compound 4, half-maximal inhibitory concentration: 50 nM
The estimate for compound 4 lay 3.6-fold (0.56 log units) above the measured number; the measured number lies below the stated range.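

In this assay, putting methoxy in place of methyl on the benzyl group gave a 6.6-fold lower number from compound 3 to compound 4 (0.82 log units; beyond the scatter), and this matches the size of the same change on the other aromatic ring: the same change on two cores in this assay, a 6.3-fold lower number (0.80 log units; beyond the scatter) from compound 1 to compound 2 and a 6.6-fold lower number (0.82 log units; beyond the scatter) from compound 3 to compound 4, 1.1-fold (0.02 log units) apart, within the scatter of two such steps. Set against the unsubstituted ring nitrogen, the whole 4-methoxybenzyl group gives a 19-fold lower number from compound 2 to compound 4 (1.28 log units; beyond the scatter), the largest step among the compounds shown, so the two methoxy groups of compound 4 sit in the compound with the lowest number of the four. This does show that, in these two pairs, the swap gave a step of the same size on two different cores, but two pairs in a single cell assay are too few to promise the same step on a further core, and they do not explain why methoxy gives lower numbers than methyl.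

The compounds shown leave open what other groups would do on the same aromatic carbon, such as a hydroxyl, a chlorine atom, an amine or a longer chain like ethoxy. They also leave open whether the step would keep its size if the group on the ring nitrogen were something other than a substituted benzyl, such as a simple ethyl chain.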